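Hydrazone series: arylamino change from compound 3 to compound 4

The compounds below may be only part of what the source reports. "The series", "measured", "known", "first", "only" and "open" are said of these compounds alone.

Three compounds of this series have been run in a functional assay on the whole organism for inhibition, with Rattus norvegicus as the target; a higher number here means that more compound is needed for the effect, a lower number that less compound is needed. Compound 1 `CC1CCC(=NNc2ccccc2)c2ncc(C(=O)O)c(=O)n21` gives 0.6 umol/kg in this assay. Compound 2 `O=C(O)c1cnc2n(c1=O)CCC/C2=N\Nc1ccccc1` gives 31.6 umol/kg in this assay, a number far higher than those of the other two and beyond the scatter. Compound 3 `CC1CC/C(=N\Nc2cccc(Cl)c2)c2ncc(C(=O)O)c(=O)n21` gives 0.6 umol/kg in this assay, level with compound 1 at the digits shown, so the two together stand lowest of the three without any order between them.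

Compound 4 `Cc1ccc(N/N=C2\CCC(C)n3c2ncc(C(=O)O)c3=O)cc1` has not yet been measured in this assay. It differs from compound 3 in one place: 4-methylphenyl in place of 3-chlorophenyl on an amine nitrogen. For the measured compounds named here, no step between measured compounds that differ in a single place is available, so the size of this change can only be expected from the values shown. Compound 1 and compound 3, which carry different groups on that amine nitrogen, sit at the same number, so no movement beyond the scatter is expected here. The step from compound 3 to compound 4 is estimated as a 1.3-fold higher number from compound 3 to compound 4 (0.12 log units; within the scatter). Compound 4 is expected to give about 0.8 umol/kg in this assay, within a range of 0.3 umol/kg to 2.5 umol/kg.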

Compound 4, dose for 50% inhibition: 1.3 umol/kg
Compound 4: the middle estimate sits 1.6-fold (0.21 log units) below what was measured, and the stated range covers the measured number.
By their numbers in this assay, from the lowest: compounds 1 and 3 (each within the scatter of the next); then compound 4; then compound 2.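

In this assay, the aryl group on the amine nitrogen now shows a step beyond the scatter: 4-methylphenyl in place of 3-chlorophenyl gives a 2.2-fold higher number from compound 3 to compound 4 (0.34 log units; beyond the scatter) and the step is modest. Compound 1 and compound 3 stand level at the digits printed, so this position had shown no movement until compound 4, and it is now clear that the aryl group here is not freely interchangeable. Nothing available explains the rise in the number.

The step swaps chlorine for methyl and also moves the substituent on the phenyl ring, so the two changes cannot be separated; 4-chlorophenyl or 3-methylphenyl on the same nitrogen would separate them. As far as these compounds go, how far the number moves with larger groups here, such as 4-methoxyphenyl or naphthyl, remains open.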